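From compound 2 to compound 3: a larger amide-nitrogen substituent

A few compounds are considered here, and "the series" means these few. Any claim that something is new, unique, unknown or untested is made for them only; others in the source may bear on it.

Among the compounds with values here, in a functional assay on L1210 cells (Mus musculus) for inhibition, read by MTT assay, with a stated time of 72 h (on this read-out higher numbers stand for weaker inhibition and lower numbers for stronger inhibition), compound 2 (`COc1cc(NC(C)CCCNC(=O)Nc2ccc(Cl)cc2)c2ncccc2c1`) gives 19000 nM, the lower of the two numbers so far, while compound 1 (`COc1cc(NC(C)CCCNC(=O)NNC(=O)Nc2ccc(Cl)cc2)c2ncccc2c1`) gives 58000 nM. Compound 3 (`COc1cc(NC(C)CCCNC(=O)NNC(=O)Nc2ccc(O)cc2)c2ncccc2c1`) is the next to be read: ((4-hydroxyphenyl)carbamoyl)amino in place of 4-chlorophenyl on an amide-type nitrogen, with ((4-hydroxyphenyl)carbamoyl)amino in place of 4-chlorophenyl on an amide-type nitrogen. Within the data shown here, one measured step bears on this, a 3.1-fold lower number from compound 1 to compound 2 (0.48 log units; beyond the scatter), which is modest but beyond the scatter. It removes a carbamoylamino unit, whereas the present change adds one, so a modest rise in the number is expected in this assay. Among the measured compounds shown here, no measured step shows the effect of the 4-hydroxyphenyl ending, which widens the range. The expected change is a 2.9-fold higher number from compound 2 to compound 3 (0.46 log units; beyond the scatter). Compound 3 is estimated at 55000 nM, with an expected range of 22000 nM to 140000 nM.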

Compound 3, half-maximal inhibitory concentration: 95000 nM
The estimate for compound 3 lay 1.7-fold (0.24 log units) below the measured number; measured number inside the range.
By their numbers in this assay, from the lowest: compound 2; then compounds 1 and 3 (each within the scatter of the next).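

In this assay, the step with ((4-hydroxyphenyl)carbamoyl)amino in place of 4-chlorophenyl on an amide-type nitrogen, a 5.0-fold higher number from compound 2 to compound 3 (0.70 log units; beyond the scatter), shows that this place tolerates the larger substituent only with a weaker read-out, and compound 2 keeps the lowest number of the set. Within the data shown here, the first direct comparison of the aromatic ending, hydroxy in place of chloro on an aromatic carbon, gives a 1.6-fold higher number from compound 1 to compound 3 (0.21 log units; within the scatter), so that exchange does not separate the two compounds in this assay. Nothing measured on these compounds accounts for either step.

Going by these compounds, it remains open whether an amine or a carboxylic acid on that aromatic carbon would give a step beyond the scatter. On these data alone, the effect of a longer chain on the amide-type nitrogen, in place of 4-chlorophenyl, also remains open.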